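The source may report more compounds than this note shows. Statements on the series, on what has been measured and on what is new or still open speak of the compounds shown alone.

Measured compounds:
compound 1 `CC(C)=CCC/C(C)=C/CC/C(C)=C/CC[C@@H]1[C@@]2(C)CC/C(=N\OCc3cn(-c4cccc([N+](=O)[O-])c4)nn3)C(C)(C)[C@@H]2CC[C@@]1(C)O`: 22000 nM
compound 2 `CC(C)=CCC/C(C)=C/CC/C(C)=C/CC[C@@H]1[C@@]2(C)CC/C(=N\OCc3cn(-c4cccc(C(F)(F)F)c4)nn3)C(C)(C)[C@@H]2CC[C@@]1(C)O`: 22700 nM
compound 3 `CC(C)=CCC/C(C)=C/CC/C(C)=C/CC[C@@H]1[C@@]2(C)C/C(=C\c3ccc(OCc4cn(-c5cccc([N+](=O)[O-])c5)nn4)cc3)C(=O)C(C)(C)[C@@H]2CC[C@@]1(C)O`: 117000 nM

In a functional assay on HepG2 cells (Homo sapiens) for cytotoxicity, read by MTT assay, with a stated time of 48 h (a higher number here means a weaker inhibitor, a lower number a stronger inhibitor), compound 1 and compound 2 sit close together: the step of a 1.0-fold higher number from compound 1 to compound 2 (0.01 log units; within the scatter) follows the change (trifluoromethyl in place of nitro on an aromatic carbon). Compound 3 gives the highest number of the three, and the difference between its core and the core of compound 1 is not broken down here. Compound 4 `CC(C)=CCC/C(C)=C/CC/C(C)=C/CC[C@@H]1[C@@]2(C)C/C(=C\c3ccc(OCc4cn(-c5cccc(C(F)(F)F)c5)nn4)cc3)C(=O)C(C)(C)[C@@H]2CC[C@@]1(C)O` is not yet measured; it differs from compound 3 by trifluoromethyl in place of nitro on an aromatic carbon, the same change as between compound 1 and compound 2, since both place descriptions read alike. Because the step of a 1.0-fold higher number from compound 1 to compound 2 (0.01 log units; within the scatter) lies within the scatter, the step of a 1.0-fold lower number from compound 3 to compound 4 (0.01 log units; within the scatter) is expected to be small as well, leaving compound 4 near compound 3. Compound 4 is therefore estimated at 115000 nM in this assay, with a likely range from 60000 nM to 230000 nM.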

Compound 4, half-maximal inhibitory concentration: 27600 nM
Estimate against measurement, compound 4: 4.2-fold (0.62 log units) above, and the stated range ends above it.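

In this assay, 3-(trifluoromethyl)phenyl in place of 3-nitrophenyl gives a 4.2-fold lower number from compound 3 to compound 4 (0.63 log units; beyond the scatter), and this step does not match the one seen on the core of compound 1: the same change on two cores in this assay, a 1.0-fold higher number (0.01 log units; within the scatter) from compound 1 to compound 2 and a 4.2-fold lower number (0.63 log units; beyond the scatter) from compound 3 to compound 4, 4.4-fold (0.64 log units) apart, beyond the scatter of two such steps

In these two pairs, then, the size of the step depends on the core, and a step read on one core did not carry over to the other. What in the cores sets the two steps apart is not shown, and two pairs give no rule for any further core.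

The compounds shown leave open how other groups on the same aromatic ring, such as a chlorine atom, a methoxy group or an amine, would behave on each core. Also open, as far as these compounds go, is whether a carboxylic acid in place of nitro would follow either step.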